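The compounds below may be only part of what the source reports. "The series", "measured", "known", "first", "only" and "open" are said of these compounds alone.

Of the compounds shown here, three sharing one core have been tested in a functional assay on A549 cells (Homo sapiens) for antiproliferative activity, read by trypan blue exclusion, with a stated time of 72 h, tested at 20 uM; a higher number here means more inhibition at the concentration tested (going by the name of the read-out), a lower number less inhibition. In this assay compound 1 `CCCCN1C(=O)NC(=O)/C1=C\c1ccccc1` gives 6.8%. In this assay compound 2 `CCCCN1C(=O)NC(=O)/C1=C/c1ccccc1` gives 18%. In this assay compound 3 `CCCCN1C(=O)NC(=O)/C1=C/c1ccc(Cl)cc1` gives 26%. Among these three numbers compound 2 stands second highest: its nearest neighbour is compound 3, higher by a margin within the scatter, and its furthest is compound 1, lower by a margin beyond the scatter. The step of a number 11.2 percentage points higher from compound 1 to compound 2 (beyond the scatter) goes with the fact that compounds 1 and 2 differ only in the configuration as drawn, the two compounds having the same atoms and bonds and differing only in how the double bond is drawn. The step of a number 8 percentage points higher from compound 2 to compound 3 (within the scatter) stays within the scatter.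

Compound 4 `CCCCCCN1C(=O)NC(=O)/C1=C/c1ccccc1` has not yet been measured. It differs from compound 2 in that (ethyl in place of hydrogen on a saturated chain carbon, four bonds along the chain from an amide-type nitrogen in a ring). Neither measured step touches this chain: one changes only the configuration, the other adds a chloro on the aromatic ring. Within the data shown here, no measured step therefore bears on lengthening the chain, and the expectation in this assay is no step beyond the scatter. Compound 4 is estimated to give 20%, within a range from 8% to 34%. This estimate amounts to an expected step of a number 2 percentage points higher from compound 2 to compound 4 (within the scatter).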

Compound 4, a percentage reported as inhibition, at one concentration (the size of the read-out at that concentration, not a potency): 0%
Compound 4: middle estimate off by 20 percentage points, on the high side; the measured number lies below the stated range.
By their numbers in this assay, from the lowest: compounds 4 and 1 (each within the scatter of the next); then compounds 2 and 3 (each within the scatter of the next).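

Placing ethyl in place of hydrogen on a saturated chain carbon, four bonds along the chain from an amide-type nitrogen in a ring, gives a number 18 percentage points lower from compound 2 to compound 4 (beyond the scatter) in this assay. Among these compounds, the earlier steps changed only the configuration of the double bond and a substituent on the aromatic ring, so this is the first sign that the chain itself matters here: with this change, compound 4 gives 0%, and a small addition of carbon is enough to leave no inhibition at the one concentration tested. Nothing measured here accounts for this step, since the only supporting fact concerns the configuration of the double bond and not the chain.

Among the compounds shown here, with only two chain lengths compared, it remains open how the number behaves for a shorter chain such as propyl, for a longer chain such as octyl, or for a chain carrying a carboxylic acid or an amine. As far as these compounds go, it is also open whether the same chain change would have a similar effect on the chloro-substituted compound 3 or on the other double-bond configuration seen in compound 1.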